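A few compounds are considered here, and "the series" means these few. Any claim that something is new, unique, unknown or untested is made for them only; others in the source may bear on it.

Working notes on the series sharing the core of compound 1 (`CC(C)CCCOc1cccc(O)c1C(=O)/C=C/c1ccc(O)cc1`). In a functional assay on HCT-15 cells (Homo sapiens) for antiproliferative activity, read by sulforhodamine B assay (on this read-out lower numbers stand for stronger inhibition of growth and higher numbers for weaker inhibition of growth), compound 1 gives 11600 nM. Compound 2 (`CC(C)=CCOc1cccc(O)c1C(=O)/C=C/c1ccc(O)cc1`) reads > 30000 nM, which is a limit and not a number. Compound 3 (`O=C(/C=C/c1ccc(O)cc1)c1c(O)cccc1OCCC1CCCCC1`) reads > 30000 nM, also a limit. Compound 3 therefore stands at the limit of > 30000 nM in this assay, at which 2 of the 3 values shown sit.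

Compound 4 (`CC(C)CCOc1cccc(O)c1C(=O)/C=C/c1ccc(O)cc1`) differs from compound 3 by one change: isopropyl in place of cyclohexyl on a saturated chain carbon, two bonds along the chain from an oxygen on an aromatic ring. It puts isopropyl in place of cyclohexyl on a saturated chain carbon, two bonds along the chain from an oxygen on an aromatic ring.

The most relevant measured step is an at least 2.5-fold higher number from compound 1 to compound 3 (0.41 log units; beyond the scatter), with cyclohexyl in place of isobutyl at that same place. Read in reverse, it points to a lower number once cyclohexyl leaves. The step of an at least 2.5-fold higher number from compound 1 to compound 2 (0.41 log units; beyond the scatter) involves a different change and only shows that this end of the molecule affects the read-out. The step that the two limits leave unreadable from compound 2 to compound 3 adds nothing.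

A modest step towards stronger inhibition of growth is therefore expected in this assay, although a result at the limit remains possible. The expected change is an at least 1.8-fold lower number from compound 3 to compound 4 (0.27 log units; that floor lies within the scatter). For compound 4 the estimate is 16000 nM, with an expected range of 8000 nM to 30000 nM.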

Compound 4, concentration for 50% growth inhibition: 10600 nM
The estimate for compound 4 lay 1.5-fold (0.18 log units) above the measured number; the range from low to high includes it.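

In this assay, isopropyl in place of cyclohexyl at the saturated chain carbon two bonds along the chain from an oxygen on an aromatic ring gives a clear gain, an at least 2.8-fold lower number from compound 3 to compound 4 (0.45 log units; beyond the scatter), and isobutyl in place of 2-methylprop-1-en-1-yl on the chain carbon bound to that oxygen gives another, an at least 2.8-fold lower number from compound 2 to compound 4 (0.45 log units; beyond the scatter). Compound 2 and compound 3 each stand at a limit, so both steps are floors and not full sizes: the limit of > 30000 nM in this assay, at which 2 of the 4 values shown sit. Isopropyl in place of isobutyl at the carbon two bonds along the chain leaves the read-out unchanged within the scatter, a 1.1-fold lower number from compound 1 to compound 4 (0.04 log units; within the scatter).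

From the compounds shown here alone, whether an amine or a carboxylic acid at the end of the chain would move the number beyond the scatter stays open. Going by these compounds, the full size of the two floor steps also stays open.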